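A few compounds are considered here, and "the series" means these few. Any claim that something is new, unique, unknown or untested is made for them only; others in the source may bear on it.

Measured in an ADME assay on liver for metabolic stability, with Liver microsome (Homo sapiens) as the target, using microsomes; on this read-out lower numbers stand for slow clearance and higher numbers for fast clearance:
- compound 1 `N#Cc1ccc(C2CCN(C(=O)Nc3cc(-c4ccccn4)n[nH]3)CC2)cc1`: 25.3 mL.min-1.g-1
- compound 2 `O=C(NCc1cccc(Cl)c1)Nc1cc(-c2ccccn2)n[nH]1`: 184 mL.min-1.g-1

Of these two, compound 1 has the lower number, and the gap to compound 2 lies beyond the scatter. Compound 3 `O=C(Nc1cc(-c2ccccn2)n[nH]1)N1CCC(c2ccc(Cl)cc2)CC1` keeps the core of compound 1 but carries chloro in place of cyano on an aromatic carbon, para to a large group: chloro in place of cyano on an aromatic carbon. For the measured compounds named here, no measured pair shows this change alone, so any prediction is uncertain. Compound 2, which also carries a chloro group, gives 184 mL.min-1.g-1, which tentatively points upward. A moderate rise in this assay is expected, estimated as a 1.8-fold higher number from compound 1 to compound 3 (0.25 log units; within the scatter). The estimate for compound 3 is 45 mL.min-1.g-1, with an expected range of 20 mL.min-1.g-1 to 100 mL.min-1.g-1.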

Compound 3, intrinsic clearance in microsomes: 30 mL.min-1.g-1
Estimate against measurement, compound 3: 1.5-fold (0.18 log units) above; the range from low to high includes it.
By their numbers in this assay, from the lowest: compounds 1 and 3 (each within the scatter of the next); then compound 2.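

In this assay the swap from 4-cyanophenyl to 4-chlorophenyl gives a 1.2-fold higher number from compound 1 to compound 3 (0.07 log units; within the scatter) and thus no readable change. On this aromatic carbon, para to a large group, cyano and chloro therefore cannot be told apart on this read-out. No measurement shown here offers an explanation for this result. Still open, from the compounds shown here alone, is how an amine, a carboxylic acid or a methoxy group on the same carbon would read. Going by these compounds, whether chloro and cyano also match on another carbon of this ring remains open too.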